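This account rests on a few compounds, and the source may have more. Where it says the series, first, only, none or still open, it means among the compounds named here.

In a functional assay on OVCAR-8 cells (Homo sapiens) for antiproliferative activity; on this read-out lower numbers stand for stronger inhibition and higher numbers for weaker inhibition:
- compound 1 `Cn1ncc(Cl)c1-c1cc(C(=O)N[C@@H]2CN[C@H](CC(=O)O)C[C@H]2c2ccc(Cl)c(Cl)c2)oc1Cl`: 5120 nM
- compound 2 `CN(C)CC[C@@H]1C[C@@H](c2ccc(Cl)c(Cl)c2)[C@H](NC(=O)c2cc(-c3c(Cl)cnn3C)c(Cl)o2)CN1`: 1510 nM
- compound 3 `Cn1ncc(Cl)c1-c1cc(C(=O)N[C@@H]2CN[C@H](CC(=O)NCC(O)CO)C[C@H]2c2ccc(Cl)c(Cl)c2)oc1Cl`: 5900 nM

Compound 3 sits level with compound 1 at the high end of these numbers, as a 1.2-fold higher number from compound 1 to compound 3 (0.06 log units; within the scatter) shows. Compound 2 lies lower, and the closest guide is a 3.9-fold higher number from compound 2 to compound 3 (0.59 log units; beyond the scatter). Compound 4 `Cn1ncc(Cl)c1-c1cc(C(=O)N[C@@H]2CN[C@H](CCN3CCCC3)C[C@H]2c2ccc(Cl)c(Cl)c2)oc1Cl` differs from compound 3 as follows: (pyrrolidin-1-yl)methyl in place of (2,3-dihydroxypropyl)carbamoyl on a saturated chain carbon bound to a saturated ring carbon. The entering (pyrrolidin-1-yl)methyl resembles the (dimethylamino)methyl of compound 2, which also stands apart from compound 1 in a 3.4-fold lower number from compound 1 to compound 2 (0.53 log units; beyond the scatter). Going by the values given here, a modest step toward a lower number is therefore expected in this assay, close in size to the one separating compound 2 from compound 3. The expected change is a 3.7-fold lower number from compound 3 to compound 4 (0.57 log units; beyond the scatter). Compound 4 is estimated at 1600 nM, with an expected range of 650 nM to 4000 nM.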

Compound 4, half-maximal inhibitory concentration: 1840 nM
Compound 4: middle estimate off by 1.2-fold (0.06 log units), on the low side, within the range that was stated.
By their numbers in this assay, from the lowest: compounds 2 and 4 (each within the scatter of the next); then compounds 1 and 3 (each within the scatter of the next).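

In this assay, on a saturated chain carbon bound to a saturated ring carbon, (pyrrolidin-1-yl)methyl gives a 3.2-fold lower number from compound 3 to compound 4 (0.51 log units; beyond the scatter) and a 2.8-fold lower number from compound 1 to compound 4 (0.44 log units; beyond the scatter), so a second amine group joins compound 2 on the low side of the series. Going by these compounds alone, the form of the amine makes no readable difference, with a 1.2-fold higher number from compound 2 to compound 4 (0.09 log units; within the scatter) as the only comparison. Nothing measured here gives a reason for these steps.

As far as these compounds go, whether a primary amine or a morpholine holds the same level stays open. So does the effect of a longer chain carrying the amine.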